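Replacing trifluoromethyl with nitro in compound 3

The source may report more compounds than this note shows. Statements on the series, on what has been measured and on what is new or still open speak of the compounds shown alone.

Measured so far in an ADME assay on Vero cells (Chlorocebus sabaeus) for cytotoxicity, read by resazurin assay, with a stated time of 72 h (on this read-out higher numbers stand for weaker inhibition and lower numbers for stronger inhibition), as follows:
Compound 1 `Cc1ccc(C(=O)CCN2CCN(c3ccc([N+](=O)[O-])cc3)CC2)cc1` gives 235000 nM
Compound 2 `O=C(CCN1CCN(c2ccc([N+](=O)[O-])cc2)CC1)c1ccc(F)cc1` gives 111000 nM
Compound 3 `O=C(CCN1CCN(c2ccc(C(F)(F)F)cc2)CC1)c1ccc(F)c(Br)c1` gives 66800 nM

In this assay compound 3 stands within the scatter of compound 2 and beneath compound 1 by more than the scatter. Compound 4 `O=C(CCN1CCN(c2ccc([N+](=O)[O-])cc2)CC1)c1ccc(F)c(Br)c1` differs from compound 3 in one place. The change nitro in place of trifluoromethyl on an aromatic carbon amounts to nitro in place of trifluoromethyl on an aromatic carbon. Among the compounds with values here, the only measured step, a 2.1-fold lower number from compound 1 to compound 2 (0.33 log units; beyond the scatter), was modest and concerned a different exchange, fluoro in place of methyl, so it bears on this change only loosely. Compound 2, which also carries nitro, gives 111000 nM within the scatter of compound 3, so no step beyond the scatter is expected. The expected change is small, an estimated 1.2-fold higher number from compound 3 to compound 4 (0.08 log units; within the scatter) at most slightly upward. For compound 4 the estimated value is 80000 nM with an expected range from 35000 nM to 180000 nM in this measurement.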

Compound 4, half-maximal inhibitory concentration: 256000 nM
Compound 4: the middle estimate sits 3.2-fold (0.51 log units) below what was measured, and the stated range ends below it.
By their numbers in this assay, from the lowest: compounds 3 and 2 (each within the scatter of the next); then compounds 1 and 4 (each within the scatter of the next).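

In this assay the exchange of trifluoromethyl for nitro at this aromatic carbon, para to a large group, gave the first step measured at this position (a 3.8-fold higher number from compound 3 to compound 4 (0.58 log units; beyond the scatter)). Bromo in place of hydrogen on an aromatic carbon also gave a step beyond the scatter (a 2.3-fold higher number from compound 2 to compound 4 (0.36 log units; beyond the scatter)), whereas 3-bromo-4-fluorophenyl in place of 4-methylphenyl stayed within it (a 1.1-fold higher number from compound 1 to compound 4 (0.04 log units; within the scatter)). No evidence is available to explain these steps. Where an amine or a nitrile at this aromatic carbon would fall remains open. So does whether the trifluoromethyl-to-nitro step holds with other groups on the carbonyl carbon.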